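The source may hold more compounds than are shown below. What is called first, only, known or untested is meant among the compounds shown, and "the series" means these compounds.

Measured so far:
compound 1, `COc1cccc(OC)c1OCCNCCOc1ccccc1OCc1cccc(Cl)c1`: 20400 nM
compound 2, `COc1cccc(OC)c1OCCNCCOc1ccccc1OCc1ccc(Cl)cc1`: 14500 nM
compound 3, `COc1cccc(OC)c1OCCNCCOc1ccccc1OCc1ccccc1[N+](=O)[O-]`: 34700 nM

All three were read in a functional assay on PC-3 cells (Homo sapiens) for cytotoxicity, read by sulforhodamine B assay; on this read-out lower numbers stand for stronger inhibition of growth and higher numbers for weaker inhibition of growth. Compound 3 returns the highest number of the three, but only against compound 2 is it clearly apart, as a 2.4-fold higher number from compound 2 to compound 3 (0.38 log units; beyond the scatter) shows; against compound 1 the step of a 1.7-fold higher number from compound 1 to compound 3 (0.23 log units; within the scatter) stays within the scatter, so those two cannot be ordered.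

Compound 4, `COc1cccc(OC)c1OCCNCCOc1ccccc1OCc1ccc([N+](=O)[O-])cc1`, has not yet been tested. It differs from compound 3 in one place: 4-nitrophenyl in place of 2-nitrophenyl on a saturated chain carbon bound to an oxygen on an aromatic ring.

Within the data shown here, no measured pair moves a nitro group around the ring, so the nearest guide is the step that moves a chloro substituent on the same ring, a 1.4-fold lower number from compound 1 to compound 2 (0.15 log units; within the scatter), which stayed within the scatter. The two steps onto compound 3, a 1.7-fold higher number from compound 1 to compound 3 (0.23 log units; within the scatter) and a 2.4-fold higher number from compound 2 to compound 3 (0.38 log units; beyond the scatter), place the 2-nitrophenyl compound no lower than either chlorophenyl compound, so there is no sign in this set that a group in this position drives large swings. The expectation for compound 4 in this assay is therefore a step of a 1.6-fold lower number from compound 3 to compound 4 (0.20 log units; within the scatter), small and most likely within the scatter, leaning if anything toward a lower number. Compound 4 is estimated at 22000 nM, with a range from 9000 nM to 55000 nM.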

Compound 4, concentration for total growth inhibition: 43600 nM
Compound 4: the middle estimate sits 2.0-fold (0.30 log units) below what was measured; the measured number falls inside the stated range.
By their numbers in this assay, from the lowest: compounds 2, 1, 3 and 4 (each within the scatter of the next, the first and the last beyond it).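

In this assay, among these compounds, a 1.3-fold higher number from compound 3 to compound 4 (0.10 log units; within the scatter) is the first step that moves a nitro group on this ring, and the 2-nitrophenyl and 4-nitrophenyl compounds cannot be ordered. The swap of nitro for chloro on an aromatic carbon, with the 4-substituted ring otherwise unchanged, gives a 3.0-fold higher number from compound 2 to compound 4 (0.48 log units; beyond the scatter) and stands beyond the scatter, so in this pair the identity of the group shifts the number more than moving the nitro group did. The step of a 2.1-fold higher number from compound 1 to compound 4 (0.33 log units; beyond the scatter) also lies beyond the scatter and places compound 4 clearly apart from both chlorophenyl compounds, although compound 3 remains inseparable from compound 1, which keeps any general statement about nitro against chloro from holding across all four compounds; no measurement shown here offers a reason for these differences.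

The compounds shown leave open how 3-nitrophenyl would compare, and whether the small step between the nitro isomers would hold for a methoxy group or a carboxylic acid on this ring. They also leave open whether an amine in place of the nitro group, or a longer chain in place of the saturated chain carbon bound to the oxygen, would move the number further.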